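Swapping a Fluorinated Ether for a Benzyl Group

This account rests on a few compounds, and the source may have more. Where it says the series, first, only, none or still open, it means among the compounds named here.

Of the compounds shown here, two have so far been measured in a functional assay on aorta for antagonist activity at Alpha-1D adrenergic receptor (Rattus norvegicus); on this read-out higher numbers stand for weaker binding and lower numbers for tighter binding. Compound 1 `COc1ccccc1N1CCN(CCCSc2ccccc2C(=O)N(C)C)CC1` gives 12.6 nM in this assay, and compound 2 `CN(C)C(=O)c1cccnc1NCCCN1CCN(c2ccccc2OCC(F)(F)F)CC1` gives 15.9 nM. Compound 2 thus has the higher of the two numbers, but its gap to compound 1 lies within the usual scatter of this kind of measurement, so the two cannot be told apart on these data alone. Compound 3 `CN(C)C(=O)c1cccnc1NCCCN1CCN(c2ccccc2Cc2ccccc2)CC1` is the next compound to be tested. It differs from compound 2 in one place: benzyl in place of 2,2,2-trifluoroethoxy on an aromatic carbon. The shared core of the three compounds is otherwise kept.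

Going by the values given here, no step between two measured compounds matches this change, so there is no direct guide to its size. Because compound 2 already sits at 15.9 nM and compound 1 with a smaller group at the same position sits at 12.6 nM, the expectation is a modest shift toward weaker binding, estimated as a 1.6-fold higher number from compound 2 to compound 3 (0.20 log units; within the scatter). Compound 3 is therefore expected to give about 25 nM in this assay, within a range from 8 nM to 80 nM.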

Compound 3, dissociation constant: 79.4 nM
Estimate against measurement, compound 3: 3.2-fold (0.50 log units) below, and the stated range covers the measured number.
By their numbers in this assay, from the lowest: compounds 1 and 2 (each within the scatter of the next); then compound 3.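

In this assay, going by these compounds alone, this position on the aromatic ring proves sensitive to what it carries: benzyl in place of 2,2,2-trifluoroethoxy brings a 5.0-fold higher number from compound 2 to compound 3 (0.70 log units; beyond the scatter), which is the first step beyond the scatter and points to weaker binding. The heavy-atom count hardly moves, from 6 to 7, but the change does several other things at once: it removes the oxygen and the three fluorines, along with the hydrogen-bond acceptor, and it adds a six-membered aromatic ring, so this single step cannot show which of these differences matters. No measured evidence is available to explain the shift.

From the compounds shown here alone, it remains open whether ethoxy, which keeps the oxygen but has no fluorine, or phenoxy, which keeps the oxygen and also carries an aromatic ring, would read closer to compound 2 or to compound 3. Also unresolved is whether a small group such as methoxy on the same core would stay close to compound 2, which would help show whether the aromatic ring of benzyl or the missing oxygen accounts for the weaker binding.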